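This account rests on a few compounds, and the source may have more. Where it says the series, first, only, none or still open, it means among the compounds named here.

In a functional assay on HT-29 cells (Homo sapiens) for cytotoxicity, read by MTT assay, with a stated time of 24 h, tested at 0.64 ug/mL (a lower number here means a weaker effect, a higher number a stronger effect of the compound at the concentration tested), three compounds that share one core have been measured. Compound 1 `CN(C)/C=C/N1CCN(CC(=O)Nc2ccc(-c3nc(-c4ccccc4)c(-c4ccccc4)n3C)cc2)CC1` gives 3.1%. Compound 2 `Cn1c(-c2ccc(NC(=O)CN3CCN(Cc4ccccc4)CC3)cc2)nc(-c2ccccc2)c1-c1ccccc1` gives 15.5%, and compound 3 `COc1ccc(CN2CCN(CC(=O)Nc3ccc(-c4nc(-c5ccccc5)c(-c5ccccc5)n4C)cc3)CC2)cc1` gives 5.2%. Compound 3 therefore stands second highest of the three: compound 1 is its nearest neighbour, and the gap between them lies within the scatter, while compound 2 is furthest from it, as shown by a number 10.3 percentage points lower from compound 2 to compound 3 (beyond the scatter).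

Compound 4 `Cn1c(-c2ccc(NC(=O)CN3CCN(Cc4ccc(Cl)cc4)CC3)cc2)nc(-c2ccccc2)c1-c1ccccc1` has not yet been measured. It differs from compound 3 by chloro in place of methoxy on an aromatic carbon. Within the data shown here, the only measured step that touches the same place is a number 10.3 percentage points lower from compound 2 to compound 3 (beyond the scatter); no measured step shows what chloro does there, so the comparison rests on that one step alone. Both compound 2 and compound 3 are modest in this assay, so compound 4 is expected to land near them, with the expected step of a number 2.8 percentage points higher from compound 3 to compound 4 (within the scatter) not clearly beyond the scatter. For compound 4 the estimate is 8%, within a range from 2% to 16%.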

Compound 4, a percentage reported as activity, at one concentration (the size of the read-out at that concentration, not a potency): 11.3%
The estimate for compound 4 lay 3.3 percentage points below the measured number; measured number inside the range.
By their numbers in this assay, from the lowest: compounds 1, 3, 4 and 2 (each within the scatter of the next, the first and the last beyond it).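

In this assay chloro in place of methoxy on this aromatic carbon gives a number 6.1 percentage points higher from compound 3 to compound 4 (within the scatter) and chloro in place of hydrogen gives a number 4.2 percentage points lower from compound 2 to compound 4 (within the scatter) so chloro cannot be told apart from either group. The earlier compounds shown here showed only that methoxy and hydrogen at this place differ beyond the scatter, and chloro does not add a third clearly separate result. On the amine nitrogen in the ring, 4-chlorobenzyl gives a number 8.2 percentage points higher from compound 1 to compound 4 (within the scatter) which stays within the scatter, whereas benzyl in the same comparison went beyond it.

Nothing shown here explains these numbers. As far as these compounds go, whether an amine, a nitrile or a carboxylic acid on this same aromatic carbon would separate clearly from hydrogen, methoxy or chloro remains open.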